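The compounds below may be only part of what the source reports. "The series", "measured", "known", "first", "only" and "open" are said of these compounds alone.

Series in an ADME assay on Vero cells (Chlorocebus sabaeus) for cytotoxicity, read by reporter gene assay, with a stated time of 4 days; a lower number here means a stronger inhibitor, a higher number a weaker inhibitor:
- compound 1 `CCCCCCCC(=O)OCC(C)(C)CC1=C(O)C(=O)c2ccccc2C1=O`: > 258000 nM, a limit of the assay
- compound 2 `CCCCCCCCCC(=O)OCC(C)(C)CC1=C(O)C(=O)c2ccccc2C1=O`: 203000 nM
- compound 3 `CCCCCCCCCCC(=O)OCC(C)(C)CC1=C(O)C(=O)c2ccccc2C1=O`: not yet measured

Among the measured compounds shown here, compound 2 carries the only actual number so far, 203000 nM. For compound 1 the reading is a limit, (the limit of > 258000 nM in this assay, at which 1 of the 2 values shown sits).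

The next change is from compound 2 to compound 3: methyl in place of hydrogen on a saturated chain carbon, nine bonds along the chain from a carbonyl carbon. In words, this is methyl in place of hydrogen on a saturated chain carbon, nine bonds along the chain from a carbonyl carbon.

For the measured compounds named here, one measured step bears on this, an extension of the same chain: an at least 1.2-fold lower number from compound 1 to compound 2 (0.10 log units; that floor lies within the scatter). Its size is known only as a floor, and one step is thin support for any trend. No step beyond the scatter is therefore expected in this assay, with at most a slight lean toward a lower number. The expected change is a 1.2-fold lower number from compound 2 to compound 3 (0.08 log units; within the scatter). For compound 3 the estimate is 170000 nM, with an expected range of 80000 nM to 280000 nM.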

Compound 3, half-maximal inhibitory concentration: > 233000 nM
Compound 3: only a limit was reported; the forecaster's own chance of this, stated with the estimate: 25%; at least 1.3-fold (0.13 log units) between middle value and limit.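

In this assay, methyl in place of hydrogen on a saturated chain carbon, nine bonds along the chain from a carbonyl carbon, gives an at least 1.1-fold higher number from compound 2 to compound 3 (0.05 log units; that floor lies within the scatter). The size of this step is known only as a floor because compound 3 is reported as a limit and not as a number: the limit of > 233000 nM in this assay, at which 1 of the 3 values shown sits.

The floor lies within the scatter, so this position adds no readable size of effect, and the lean toward a lower number in the earlier chain extension finds no measured continuation here; the step from compound 1 to compound 3 cannot be read, since both compounds carry limits.

Among the compounds shown here, compound 2 therefore remains the only compound in this short series with an actual number, and no trend with chain length can be drawn from the three compounds. Open is whether a longer chain, or an amine or a carboxylic acid in place of the methyl, would give a number rather than a limit in this assay, and the shared core stays the same throughout, so the compounds shown say nothing about changes to it.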